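Working notes: compound 3 to compound 4 on the shared core

The source may report more compounds than this note shows. Statements on the series, on what has been measured and on what is new or still open speak of the compounds shown alone.

Numbers in a functional assay on BJAB cells (Homo sapiens) for antiproliferative activity, with a stated time of 4 days (a higher number here means that more compound is needed for the effect, a lower number that less compound is needed), so far:
compound 1 `Cc1nn(-c2nc(-c3ccc(Cl)c(Cl)c3)c(SC(C)C)s2)c(C(=O)O)c1-c1cncnc1`: 22000 nM
compound 2 `Cc1nn(-c2nc(-c3ccc(Cl)c(Cl)c3)c(SC(C)C)s2)c(C(=O)O)c1-c1ccccc1[N+](=O)[O-]`: 4700 nM
compound 3 `Cc1nn(-c2nc(-c3ccc(Cl)c(Cl)c3)c(SC(C)C)s2)c(C(=O)O)c1-c1cnccn1`: 14000 nM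

Compound 3 stands second highest of the three numbers; to compound 1 it lies within the scatter, as a 1.6-fold lower number from compound 1 to compound 3 (0.20 log units; within the scatter) shows, while to compound 2 it lies beyond it, as a 3.0-fold higher number from compound 2 to compound 3 (0.47 log units; beyond the scatter) shows. Compound 4 `Cc1nn(-c2nc(-c3ccc(Cl)c(Cl)c3)c(SC(C)C)s2)c(C(=O)O)c1-c1ccc(C(F)(F)F)cc1` differs from compound 3 in one place: 4-(trifluoromethyl)phenyl in place of pyrazin-2-yl on an aromatic carbon. Within the data shown here, no measured step covers 4-(trifluoromethyl)phenyl itself. Among the measured compounds shown here, the steps that bear on it are those toward a six-membered aromatic ring of carbon only, a 4.7-fold lower number from compound 1 to compound 2 (0.67 log units; beyond the scatter) and a 3.0-fold higher number from compound 2 to compound 3 (0.47 log units; beyond the scatter), both modest and both favouring the ring of carbon only with lower numbers. A modest downward step in this assay is therefore expected for compound 4, estimated at 5000 nM with a range from 1500 nM to 16000 nM. The expected step is a 2.8-fold lower number from compound 3 to compound 4 (0.45 log units; beyond the scatter).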

Compound 4, half-maximal effective concentration: 3500 nM
Compound 4: the middle estimate sits 1.4-fold (0.15 log units) above what was measured, and the stated range covers the measured number.
By their numbers in this assay, from the lowest: compounds 4 and 2 (each within the scatter of the next); then compounds 3 and 1 (each within the scatter of the next).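

In this assay, the 4-(trifluoromethyl)phenyl group gives lower numbers than either ring containing nitrogen (a 4.0-fold lower number from compound 3 to compound 4 (0.60 log units; beyond the scatter); a 6.3-fold lower number from compound 1 to compound 4 (0.80 log units; beyond the scatter)). It also stands level with the 2-nitrophenyl group (a 1.3-fold lower number from compound 2 to compound 4 (0.13 log units; within the scatter)), so two differently substituted carbon-only rings now share this position's low end, with no compound shown going against that split. No supporting data explain these steps. Open, on these data alone, is whether a plain phenyl ring would stay level with these two, and whether an amine or a carboxylic acid on the ring would keep the number this low.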